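The source may report more compounds than this note shows. Statements on the series, on what has been measured and on what is new or still open speak of the compounds shown alone.

Of the compounds shown here, three have been measured in a functional assay on A549 cells (Homo sapiens) for antiproliferative activity, read by CCK-8 assay, with a stated time of 72 h; a lower number here means a stronger inhibitor, a higher number a weaker inhibitor. Compound 1 `O=C(NO)c1ccc(COc2ccccc2)cc1` gives 28000 nM in this assay. Compound 2 `Nc1ccccc1NC(=O)/C=C/c1ccc(CN2CCc3ccccc32)cc1` gives 13400 nM in this assay. Compound 3 `Nc1ccccc1NC(=O)c1ccc(COc2ccc(F)cc2)cc1` gives 5370 nM in this assay, the lowest of the three numbers; its gap to compound 2 and its wider gap to compound 1 are both beyond the usual scatter, so compound 3 stands as the strongest inhibitor of the set.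

Compound 4 `COc1ccc(OCc2ccc(C(=O)Nc3ccccc3N)cc2)cc1` has not yet been measured in this assay. It differs from compound 3 in one place: methoxy in place of fluoro on an aromatic carbon. Among the compounds with values here, since the three measured compounds differ from one another in several places at once, no single step of this kind is available for comparison, so the size of the change that this swap brings cannot be read from the numbers so far. The methoxy group is expected to behave much like the fluoro in this setting, with a step from compound 3 to compound 4 that is estimated as small, a 1.0-fold higher number from compound 3 to compound 4 (0.01 log units; within the scatter), and possibly not beyond the scatter at all. Compound 4 is therefore estimated to give about 5500 nM in this assay, within a range from 2200 nM to 14000 nM.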

Compound 4, half-maximal inhibitory concentration: 5530 nM
Compound 4: the middle estimate sits 1.0-fold (0.00 log units) below what was measured; low and high end bracket the measured number.
By their numbers in this assay, from the lowest: compounds 3 and 4 (each within the scatter of the next); then compound 2; then compound 1.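

Within the data shown here, the pair compound 3 and compound 4 gives the first comparison in the set that differs in one place only: in this assay, the change from 4-fluorophenyl to 4-methoxyphenyl gives a 1.0-fold higher number from compound 3 to compound 4 (0.01 log units; within the scatter). At this aromatic carbon, para to a large group, methoxy can therefore take the place of fluoro, although it brings a hydrogen-bond acceptor that fluoro does not count, with no difference beyond the usual scatter. No measurement offered here bears on why the two compounds read alike.

The compounds shown leave open whether an amine or a carboxylic acid on the same carbon would also leave the number within the scatter. They also leave open whether the change from fluoro to methoxy would read the same on the core of compound 1 or of compound 2.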